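This account rests on a few compounds, and the source may have more. Where it says the series, first, only, none or still open, it means among the compounds named here.

Compound 1 `O=C1/C(=C/c2ccccc2F)CCc2ccc(O)cc21` is the starting point of this short series. In a functional assay on RAW264.7 cells (Mus musculus) for inhibition (a lower number here means a stronger inhibitor, a higher number a weaker inhibitor), compound 1 gives 1350 nM. Compound 2 `O=C1/C(=C/c2ccccc2Cl)CCc2ccc(O)cc21` carries a chloro group where compound 1 carries a fluoro group, and in this assay compound 2 gives 270 nM. Going by the values given here, the step of a 5.0-fold lower number from compound 1 to compound 2 (0.70 log units; beyond the scatter) is the only measured step, and it leaves compound 2 with the lowest of the two numbers in this assay, with compound 1 as its sole neighbour.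

Compound 3 `O=C1/C(=C/c2ccccc2Br)CCc2ccc(O)cc21` is not yet measured. It differs from compound 2 by bromo in place of chloro on an aromatic carbon; the change sits ortho to a large group, on a six-membered aromatic ring of carbon only. Among the compounds with values here, the one step that bears on this change is a 5.0-fold lower number from compound 1 to compound 2 (0.70 log units; beyond the scatter), in which one halogen replaced another at the same position and the number fell by a modest amount. A second exchange of the same kind is expected to move the number in the same direction, but by less, so that the estimated step of a 1.6-fold lower number from compound 2 to compound 3 (0.20 log units; within the scatter) may not clear the scatter. The estimate for compound 3 in this assay is therefore 170 nM, with a range from 50 nM to 600 nM.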

Compound 3, half-maximal inhibitory concentration: 500 nM
Estimate against measurement, compound 3: 2.9-fold (0.47 log units) below; the range from low to high includes it.
By their numbers in this assay, from the lowest: compounds 2 and 3 (each within the scatter of the next); then compound 1.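

In this assay the exchange of chloro for bromo on this aromatic carbon gives a 1.9-fold higher number from compound 2 to compound 3 (0.27 log units; within the scatter) and so does not separate the two groups, which means the drop seen on leaving fluoro does not continue as a steady run along the halogens. Bromo in place of fluoro gives a 2.7-fold lower number from compound 1 to compound 3 (0.43 log units; beyond the scatter) and so repeats, with a second group, the separation from compound 1 that chloro had shown, leaving fluoro as the one group at this position set apart from the others. Nothing offered here accounts for why fluoro stands apart from chloro and bromo.

The compounds shown leave open whether a group that is not a halogen, such as methyl, methoxy or an amine, would keep the number at this position level with compound 2 and compound 3 or move it away from them. They also leave open whether chloro and bromo elsewhere on the same ring would again match each other, and what a methoxy group in place of the hydroxyl of the shared core would do.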